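The compounds below may be only part of what the source reports. "The series", "measured", "known", "first", "only" and "open" are said of these compounds alone.

Compound 2, with the structure `CC(C)(N)C(=O)N[C@H](COCc1ccc(OC(F)(F)F)cc1)c1nnnn1CCOC(=O)NCCCCO`, gives 33.2 nM in a functional assay on cells for inhibition of growth hormone secretagogue receptor type 1 (Homo sapiens), read by FLIPR and calcium flux (on this read-out lower numbers stand for an effect already at smaller amounts and higher numbers for an effect only at larger amounts of compound), and so stands at the higher of the two numbers recorded. Compound 1, with the structure `CC(C)(N)C(=O)N[C@H](COCc1ccccc1Cl)c1nnnn1CCOC(=O)NCCCCO`, gives 0.45 nM. The step of a 74-fold higher number from compound 1 to compound 2 (1.87 log units; beyond the scatter) is the only one measured here; it shows that the aryl group on this benzyl ether carries much of the activity. Compound 3, with the structure `CC(C)(N)C(=O)N[C@H](COCc1ccccc1C#N)c1nnnn1CCOC(=O)NCCCCO`, returns to a 2-substituted ring: its change is 2-cyanophenyl in place of 4-(trifluoromethoxy)phenyl on a saturated chain carbon bound to an oxygen on a saturated carbon. Within the data shown here, no measured step covers 2-cyanophenyl, but since compound 1 with 2-chlorophenyl gave 0.45 nM, a move back toward smaller numbers is expected. The step of a 17-fold lower number from compound 2 to compound 3 (1.22 log units; beyond the scatter) is therefore estimated to run in the direction of lower numbers, largely undoing the step from compound 1 to compound 2, though with wide uncertainty. Compound 3 is expected to give about 2 nM, in a range from 0.5 nM to 10 nM.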

Compound 3, half-maximal effective concentration: 1.26 nM
For compound 3 the middle estimate is 1.6-fold (0.20 log units) above the measured one; the measured number falls inside the stated range.
By their numbers in this assay, from the lowest: compound 1; then compound 3; then compound 2.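

With 2-cyanophenyl in place of 4-(trifluoromethoxy)phenyl, the result runs a 26-fold lower number from compound 2 to compound 3 (1.42 log units; beyond the scatter), so the low numbers at this position are not confined to the 2-chlorophenyl of compound 1. The exchange of chloro for cyano on an aromatic carbon is far smaller, a 2.8-fold higher number from compound 1 to compound 3 (0.45 log units; beyond the scatter), but it still lies beyond the scatter, so the two 2-substituted rings are close without being equivalent. Nothing available explains either step.

The compounds shown leave open whether the large step follows from the group itself or from where it sits, as 2-cyanophenyl and 4-(trifluoromethoxy)phenyl differ in both. A 4-cyanophenyl or 2-(trifluoromethoxy)phenyl group would separate the two, and an unsubstituted phenyl would show what either group adds.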